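Swapping a hydroxyphenyl sulfone for a dichlorophenyl sulfone

The source may hold more compounds than are shown below. What is called first, only, known or untested is meant among the compounds shown, and "the series" means these compounds.

The study examines three measured analogues sharing one core. Compound 1 `Cn1c(=O)c(S(=O)(=O)c2ccc(F)cc2F)cc2cnc(Nc3cccc4[nH]ccc34)nc21` is inhibited in a functional assay on DU-145 cells (Homo sapiens) for inhibition, read by trypan blue exclusion, with a stated time of 72 h (on this read-out higher numbers stand for weaker inhibition and lower numbers for stronger inhibition), with a value of 750 nM. Compound 2 `Cn1c(=O)c(S(=O)(=O)c2ccc(O)cc2)cc2cnc(Nc3ccc4[nH]ccc4c3)nc21` gives 250 nM in this assay, and compound 3 `Cn1c(=O)c(S(=O)(=O)c2ccccc2)cc2cnc(Nc3ccc4ncccc4c3)nc21` gives 50000 nM. Among these three, compound 2 stands lowest: its number is beyond the scatter from both compound 1 and compound 3, so it is the most potent of the set as measured.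

The step under consideration leads from compound 2 to compound 4 `Cn1c(=O)c(S(=O)(=O)c2ccc(Cl)cc2Cl)cc2cnc(Nc3ccc4[nH]ccc4c3)nc21`, which has not yet been measured in this assay. The change is 2,4-dichlorophenyl in place of 4-hydroxyphenyl on a sulfonyl sulfur. Among the measured compounds shown here, no measured pair in the set shares this exact change, so no directly comparable step is available; compound 1 carries a 2,4-difluorophenyl on the sulfonyl sulfur but also a different indole attachment, and compound 3 differs in two places as well.

Given only the spread from compound 2 to compound 1 and compound 3, a modest loss of potency is expected for compound 4, with the step of a 2.4-fold higher number from compound 2 to compound 4 (0.38 log units; beyond the scatter) estimated to lie near or somewhat beyond the scatter. Compound 4 is therefore expected to give about 600 nM in this assay, within a range from 150 nM to 3000 nM.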

Compound 4, half-maximal inhibitory concentration: 1000 nM
Beside the measured number, compound 4's estimate is 1.7-fold (0.22 log units) below it, and the stated range covers the measured number.
By their numbers in this assay, from the lowest: compound 2; then compounds 1 and 4 (each within the scatter of the next); then compound 3.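

Among the compounds shown here, with the rest of the molecule unchanged, this is the first single-place change available for the sulfonyl position. In this assay the step is a 4.0-fold higher number from compound 2 to compound 4 (0.60 log units; beyond the scatter) and is modest, so 2,4-dichlorophenyl in place of 4-hydroxyphenyl on the sulfonyl sulfur weakens inhibition without abolishing it. The entering group has 0 hydrogen-bond donors and 0 hydrogen-bond acceptors where the leaving group has 1 hydrogen-bond donor and 1 hydrogen-bond acceptor, yet compound 4 still gives 1000 nM in this read-out, although nothing measured here explains the step or ties it to any one feature of the two groups.

The compounds shown leave open whether the hydroxyl or the chlorines account for the step, since a phenyl ring carrying a single chlorine, an amine or a carboxylic acid on the sulfonyl sulfur would be needed to separate those contributions. They also leave open whether the same exchange would produce a step of similar size on the different amine substituent of compound 1.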